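Methyl for Chloro in a Glutamate Receptor Modulator Series

This account rests on a few compounds, and the source may have more. Where it says the series, first, only, none or still open, it means among the compounds named here.

Of the compounds shown here, three of the shared core have been tested in an assay on HEK293 cells for positive allosteric modulation of metabotropic glutamate receptor 3 (Rattus norvegicus), read by thallium flux, with a stated time of 2.5 min; a lower number here means that less compound is needed, a higher number that more compound is needed for the effect. Compound 1 `COc1cc(C(=O)O)ccc1OCCCCOc1ccc(C(=O)CC(C)C)c(O)c1C` gives 614 nM and compound 3 `CCCC(=O)c1ccc(OCCCCOc2cc(C(=O)O)ccc2OC)c(C)c1O` gives 496 nM in this assay. Compound 2 `Cc1c(OCCCCOc2ccc(C(=O)O)cc2Cl)ccc(C(=O)CC2CCCC2)c1O` reaches only the limit of the measurement, > 10000 nM, so no exact number is known for it. Compound 4 `Cc1cc(C(=O)O)ccc1OCCCCOc1ccc(C(=O)CC2CCCC2)c(O)c1C` differs from compound 2 by methyl in place of chloro on an aromatic carbon. For the measured compounds named here, no single-change step between measured compounds is available, so the size of this step rests on no measured pair. Because compound 2 stands at the limit of > 10000 nM in this assay, at which 1 of the 3 values shown sits, the move to compound 4 is expected to bring the number within the measurable range, though by how much is uncertain. Compound 4 is expected to give about 4000 nM, between 800 nM and 20000 nM. This amounts to an expected step of an at least 2.5-fold lower number from compound 2 to compound 4 (0.39 log units; beyond the scatter).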

Compound 4, half-maximal effective concentration: > 10000 nM
Compound 4 gave a limit, no number; the forecaster's own chance of this, stated with the estimate: 45%; middle value at least 2.5-fold (0.39 log units) away from the limit.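

For the compounds shown here, compound 2 and compound 4 each give only a limit, not a number, and no step between them can be read. Left open is whether methyl in place of chloro changes the number at all, since both compounds sit at the same limit: the limit of > 10000 nM in this assay, at which 2 of the 4 values shown sit.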